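Shortening the bromoalkyl chain on a weak isoflavone ether

This account rests on a few compounds, and the source may have more. Where it says the series, first, only, none or still open, it means among the compounds named here.

Four compounds share one core, and they differ in the chain hung from an oxygen on an aromatic ring. Compound 1 `COc1ccc(-c2coc3cc(OCCCCSC(=S)N4CCN(C(=O)OC(C)(C)C)CC4)ccc3c2=O)cc1` carries a four-carbon chain ending in a thiocarbamate, and in a functional assay on MGC-803 cells (Homo sapiens) for inhibition, read by MTT assay, with a stated time of 48 h (a higher number here means a weaker inhibitor, a lower number a stronger inhibitor), compound 1 gives 31300 nM. Compound 3 `COc1ccc(-c2coc3cc(OCCCSC(=S)N4CCN(C(=O)OC(C)(C)C)CC4)ccc3c2=O)cc1` carries the same end group on a three-carbon chain, and in this assay compound 3 gives 6070 nM. Compound 2 `COc1ccc(-c2coc3cc(OCCCCCBr)ccc3c2=O)cc1` instead ends in a bromine on a five-carbon chain. In this assay compound 2 gives > 100000 nM, which is a limit of the assay and not a number; its entry sits at the limit of > 100000 nM in this assay, at which 1 of the 3 values shown sits, so nothing more than weak activity can be read from it.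

Compound 4 `COc1ccc(-c2coc3cc(OCCCBr)ccc3c2=O)cc1` has not yet been measured. It differs from compound 2 in one place: bromo in place of 2-bromoethyl on a saturated chain carbon, three bonds along the chain from an oxygen on an aromatic ring. The chain shrinks by two carbons while the bromine stays at its end. Among the measured compounds shown here, no step between two measured compounds is available to say what such a shortening does here. Compound 4 is therefore expected to remain a weak inhibitor, with the step from compound 2 to compound 4 estimated at an at least 1.2-fold lower number from compound 2 to compound 4 (0.09 log units; that floor lies within the scatter). The expected value for compound 4 is 80000 nM, within a range from 20000 nM to 300000 nM.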

Compound 4, half-maximal inhibitory concentration: 64900 nM
Estimate against measurement, compound 4: 1.2-fold (0.09 log units) above; low and high end bracket the measured number.
By their numbers in this assay, from the lowest: compound 3; then compound 1; then compound 4. At a limit, above all of these: compound 2.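

In this assay compound 4 gives 64900 nM, so the 3-bromopropyl chain yields a true number, which the 5-bromopentyl chain of compound 2 did not provide. Shortening the chain at this position gives an at least 1.5-fold lower number from compound 2 to compound 4 (0.18 log units; that floor lies within the scatter), so the data support only a lower bound on the change, and that bound does not establish a real gain in activity. The true size of the step stays unknown because the value of compound 2 is a limit and not a number: the limit of > 100000 nM in this assay, at which 1 of the 4 values shown sits.

The compounds shown leave open how activity changes with each single carbon, since a 4-bromobutyl chain on the same core would give a further point on this series and could show whether the change is gradual or abrupt. They also leave open how much the bromine itself matters at the end of the shorter chain, which an amine or a carboxylic acid in its place on the same chain would begin to answer.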